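The source may report more compounds than this note shows. Statements on the series, on what has been measured and on what is new or still open speak of the compounds shown alone.

Measured so far:
- compound 1 `COC(=O)/C=C/c1cccc(N(Cc2ccc(-c3ccc(SC)cc3)cc2)C(=O)C(C)C)c1` — in an assay on isolated protein with Bile acid receptor (Homo sapiens) as the target (on this read-out lower numbers stand for an effect already at smaller amounts and higher numbers for an effect only at larger amounts of compound), compound 1 gives 51 nM
- compound 2 `COC(=O)/C=C/c1cccc(N(Cc2ccc(-c3ccc(OC)cc3)cc2)C(=O)C(C)C)c1` — in this assay compound 2 gives 97 nM

Within the data shown here, compound 2 has the higher of the two numbers, with compound 1 the only neighbour; the single measured step, a 1.9-fold higher number from compound 1 to compound 2 (0.28 log units; within the scatter), lies within the scatter, so the two compounds are not separated on this read-out.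

Compound 3 `COC(=O)/C=C/c1cccc(N(Cc2ccc(-c3cc(Cl)ccc3OC)cc2)C(=O)C(C)C)c1` is not yet measured. The change from compound 2 is 5-chloro-2-methoxyphenyl in place of 4-methoxyphenyl on an aromatic carbon. Among the measured compounds shown here, no measured step bears directly on it: the one known step concerns an exchange of methoxy for methylsulfanyl and says nothing about a chloro substituent or a shifted methoxy. The expectation therefore rests on the series staying in the same range, with a wide band; a step of a 1.5-fold higher number from compound 2 to compound 3 (0.19 log units; within the scatter) is expected, within the scatter in either direction. For compound 3 in this assay the estimate is 150 nM, between 40 nM and 600 nM.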

Compound 3, half-maximal effective concentration: 226 nM
For compound 3 the middle estimate is 1.5-fold (0.18 log units) below the measured one; the range from low to high includes it.
By their numbers in this assay, from the lowest: compounds 1 and 2 (each within the scatter of the next); then compound 3.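

In this assay, this position on the shared core now gives steps beyond the scatter, which the exchange of methylsulfanyl for methoxy did not: 5-chloro-2-methoxyphenyl in place of 4-methoxyphenyl gives (a 2.3-fold higher number from compound 2 to compound 3 (0.37 log units; beyond the scatter)), and the same group in place of 4-(methylsulfanyl)phenyl gives (a 4.4-fold higher number from compound 1 to compound 3 (0.65 log units; beyond the scatter)). Both steps run towards a higher number and are modest in size, so compound 3 stands apart from compound 1 and compound 2, which remain unseparated from each other. Nothing available accounts for these steps.

The change to 5-chloro-2-methoxyphenyl alters the chloro substituent and the methoxy placement together, and the compounds shown do not tell these two apart. Also open, on these data alone, is how this read-out responds to an amine on this ring, or to a carboxylic acid in place of the methyl ester.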